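Oxime series: removing fluoro from compound 3

A few compounds are considered here, and "the series" means these few. Any claim that something is new, unique, unknown or untested is made for them only; others in the source may bear on it.

Values measured in an assay on J774 cells for inhibition of prostaglandin G/H synthase 1 (Mus musculus), read by immunoassay, with stated times of 15 min and 30 min; a lower number here means a stronger inhibitor, a higher number a weaker inhibitor:
- compound 1 `Cc1c(C=O)cc(-c2ccc(S(C)(=O)=O)cc2)n1-c1ccccc1` gives > 10000 nM, a limit of the assay.
- compound 2 `Cc1c(/C=N\O)cc(-c2ccc(S(C)(=O)=O)cc2)n1-c1ccc(F)cc1` gives > 10000 nM, a limit of the assay.
- compound 3 `Cc1c(/C=N\O)cc(-c2ccc(S(C)(=O)=O)cc2)n1-c1cccc(F)c1` gives > 10000 nM, a limit of the assay.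

Compound 3 stands at the limit and nowhere else: for compound 3 only a limit and no number was recorded in this assay, and the two other values sit at the same place, (the limit of > 10000 nM in this assay, at which 3 of the 3 values shown sit). For the measured compounds named here, the one step measured within the set, a step that the two limits leave unreadable from compound 2 to compound 3, runs between two limits and yields no size.

Compound 4 `Cc1c(/C=N\O)cc(-c2ccc(S(C)(=O)=O)cc2)n1-c1ccccc1` differs from compound 3 by hydrogen in place of fluoro on an aromatic carbon; cut one bond further out, the change reads 3-fluorophenyl to phenyl. Going by the values given here, no measured step bears directly on this change, and nothing in the set tells how taking the fluoro off compound 3 shifts the number. Compound 1, which also carries the phenyl, sits at the limit as well.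

On this basis compound 4 is expected to remain at or near the limit, estimated at 15000 nM with a range of 5000 nM to 50000 nM. The step that the limit leaves unreadable from compound 3 to compound 4 is therefore expected to be none beyond the scatter, most likely read once more as a limit.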

Compound 4, half-maximal inhibitory concentration: > 10000 nM
Compound 4 gave a limit, no number (the forecaster's own chance of this, stated with the estimate: 85%); the middle value does not contradict the limit.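

The steps from compound 1, compound 2 and compound 3 to compound 4 cannot be read in this assay, because each of these compounds gives a limit and no number: the limit of > 10000 nM in this assay, at which 4 of the 4 values shown sit.

The compounds shown leave open whether removing the fluoro, or changing 4-fluorophenyl to 3-fluorophenyl, shifts the inhibition at all.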